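The source may report more compounds than this note shows. Statements on the series, on what has been measured and on what is new or still open speak of the compounds shown alone.

Compound 1 `Cc1ccncc1C(=O)N1CC(Oc2cncc(N3C(=O)c4ccc(Cl)cc4C3(C)C)c2)C1` gives 4 nM in an assay on cells for inhibition of cytochrome P450 11B2, mitochondrial (Homo sapiens), read by HTRF; on this read-out lower numbers stand for stronger inhibition and higher numbers for weaker inhibition.
Compound 3 `CC1CN(c2cccnc2)C(=O)c2ccc(Cl)cc21` gives 164 nM in this assay.
Compound 2 `Cc1cc(Cl)ccc1C(=O)N(C)c1cccnc1` gives only a limit, > 3000 nM, in this assay (the limit of > 3000 nM in this assay, at which 1 of the 3 values shown sits).

Compound 1 thus holds the lowest of the two numbers in this assay, with compound 3 beyond the scatter above it. Within the data shown here, no pair among the measured compounds differs in only one place, so no measured step is available. Compound 4 `CCS(=O)(=O)N1CC(Oc2cncc(N3C(=O)c4ccc(Cl)cc4C3(C)C)c2)C1` differs from compound 1 by ethylsulfonyl in place of (4-methylpyridin-3-yl)carbonyl on an amine nitrogen in a ring. Among the measured compounds shown here, with no measured step to rest on, a weakening is expected for compound 4, larger than the scatter but short of the limit, the step from compound 1 to compound 4 estimated at a 7.5-fold higher number from compound 1 to compound 4 (0.88 log units; beyond the scatter). Compound 4 is expected at 30 nM, within 6 nM to 150 nM.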

Compound 4, half-maximal inhibitory concentration in the cytochrome P450 11B2, mitochondrial assay: 4 nM
Estimate against measurement, compound 4: 7.5-fold (0.88 log units) above; measured number below the stated range.
By their numbers in the cytochrome P450 11B2, mitochondrial assay, from the lowest: compounds 1 and 4 (each within the scatter of the next); then compound 3. At a limit, above all of these: compound 2.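

In the cytochrome P450 11B2, mitochondrial assay, ethylsulfonyl in place of (4-methylpyridin-3-yl)carbonyl on the amine nitrogen of the four-membered ring gives no change at the digits printed from compound 1 to compound 4 (within the scatter). This position therefore accepts a group with no ring and fewer heavy atoms, so the aromatic ring of the leaving group is not required for this read-out. The two compounds separate instead in a physicochemical assay for solubility, in phosphate buffer, with a stated time of 2 h, at pH 6.5; on this read-out lower numbers stand for lower solubility and higher numbers for higher solubility: the measured solubility of compound 1, 290 ug/mL, and of compound 4, 78 ug/mL, a 3.7-fold lower number (0.57 log units; beyond the scatter). In the physicochemical assay compound 1 gives 290 ug/mL and compound 4 gives 78 ug/mL.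

Only these two groups on this nitrogen can be compared. Going by these compounds, whether a methylsulfonyl or a morpholine-bearing carbonyl would hold the inhibition and also match the solubility of compound 1 stays open.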